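This account rests on a few compounds, and the source may have more. Where it says the series, first, only, none or still open, it means among the compounds named here.

Of the compounds shown here, two have been measured in an assay on isolated protein for inhibition of Amine oxidase [flavin-containing] A (Homo sapiens), read by Amplex Red, with a stated time of 15 min, tested at 100 uM; a lower number here means less inhibition, a higher number more inhibition at the concentration tested (going by the name of the read-out). Compound 1 `CC(=O)c1ccc(OCc2ccccc2[N+](=O)[O-])cc1` gives 34%, and compound 2 `CC(=O)c1cccc(OCc2cccc(Br)c2)c1` gives 49.1%. Compound 2 therefore stands highest of the two numbers, and compound 1 sits lower by a gap beyond the usual scatter. Compound 3 `CC(=O)c1cccc(OCc2cccc([N+](=O)[O-])c2)c1` is not yet measured. It differs from compound 2 in one place: nitro in place of bromo on an aromatic carbon. For the measured compounds named here, no step of this kind has been measured here, so the step is only estimated, and the expected step is a number 7.1 percentage points lower from compound 2 to compound 3 (within the scatter), partly because compound 1 with its nitro gives 34%. In this assay compound 3 is expected to give about 42%, somewhere between 22% and 60%.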

Compound 3, a percentage reported as inhibition, at one concentration (the size of the read-out at that concentration, not a potency): 17.8%
Compound 3: middle estimate off by 24.2 percentage points, on the high side; the whole stated range lies above it.
By their numbers in this assay, from the lowest: compound 3; then compound 1; then compound 2.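

In this assay, for the compounds shown here, nitro in place of bromo on this aromatic carbon, meta to a large group, is the first single change that can be read, and it gives a number 31.3 percentage points lower from compound 2 to compound 3 (beyond the scatter) so what sits at this position clearly matters. Of these two groups, bromo keeps the more inhibition at the concentration tested. Nothing measured here says why the change has this size.

The compounds shown leave open how an amine, a methoxy group or a plain hydrogen on this same carbon would read. They also leave open whether chlorine or another halogen would hold the inhibition seen with bromo.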